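This account rests on a few compounds, and the source may have more. Where it says the series, first, only, none or still open, it means among the compounds named here.

Compound 1, `CN1CCN(CCCCCn2c3c(c4ccccc42)C(=O)c2c[n+]([O-])c4ccccc4c2C3=O)CC1`, gives 830 nM in a functional assay on SH-SY5Y cells (Homo sapiens) for cytotoxicity, read by MTT assay, with a stated time of 72 h; a higher number here means a weaker inhibitor, a lower number a stronger inhibitor.
Compound 2, `O=C1c2c[n+]([O-])c3ccccc3c2C(=O)c2[nH]c3ccccc3c21`, gives 1380 nM.
Compound 3, `CC1(C)OC[C@H](Cn2cc(Cn3c4c(c5ccccc53)C(=O)c3c[n+]([O-])c5ccccc5c3C4=O)nn2)O1`, gives 820 nM.

Among these three numbers compound 1 holds the second highest; compound 3 lies nearest to it and compound 2 furthest, yet both gaps are within the scatter, so no ordering among the three can be claimed. For the measured compounds named here, the one single-point step that is known, from the side chain of compound 1 to the bare ring nitrogen of compound 2, reads a 1.7-fold higher number from compound 1 to compound 2 (0.22 log units; within the scatter). Compound 4, `CCCN1CCN(CCCCn2c3c(c4ccccc42)C(=O)c2c[n+]([O-])c4ccccc4c2C3=O)CC1`, differs from compound 1 in a smaller way: 4-propylpiperazin-1-yl in place of (4-methylpiperazin-1-yl)methyl on a saturated chain carbon, four bonds along the chain from an aromatic nitrogen. Going by the values given here, no measured pair shows this exact exchange of a piperazine substituent together with a shortening of the chain. What the data do show is that even removing the whole chain, in the step from compound 1 to compound 2, stayed within the scatter, and that the quite different chain of compound 3 gives a number indistinguishable from compound 1. It is therefore expected that compound 4 shows no step beyond the scatter in this assay, with a 1.0-fold higher number from compound 1 to compound 4 (0.01 log units; within the scatter) as the estimated step. Compound 4 is thus estimated at 850 nM, expected to fall between 400 nM and 1800 nM.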

Compound 4, half-maximal inhibitory concentration: 3970 nM
Beside the measured number, compound 4's estimate is 4.7-fold (0.67 log units) below it; the measured number lies above the stated range.
By their numbers in this assay, from the lowest: compounds 3, 1 and 2 (each within the scatter of the next); then compound 4.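

In this assay, for the compounds shown here, the exchange on a saturated chain carbon, four bonds along the chain from an aromatic nitrogen, gives a 4.8-fold higher number from compound 1 to compound 4 (0.68 log units; beyond the scatter), the first step here to lie beyond the scatter, whereas removing the whole side chain gave only a 1.7-fold higher number from compound 1 to compound 2 (0.22 log units; within the scatter), which stayed within it. This position is therefore not indifferent to change, even though 4-propylpiperazin-1-yl keeps the six-membered non-aromatic ring and the same hydrogen-bond donor and acceptor counts as the group it replaces, and the mere presence of a side chain does not settle the number in this assay. No measurement that bears on the reason for this step is at hand.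

The exchange alters the chain length and the piperazine substituent together, so the compounds shown leave open which of the two accounts for the step; a propyl-bearing piperazine on the pentyl chain of compound 1, or a methyl-bearing piperazine on the shorter chain of compound 4, would separate them. Also open, as far as these compounds go, is how a hexyl chain, or a morpholine ring in place of the piperazine, would read at this position.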